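Thiophen-2-yl in Place of 2-Hydroxyphenyl

The source may report more compounds than this note shows. Statements on the series, on what has been measured and on what is new or still open speak of the compounds shown alone.

In a functional assay on microsomes for inhibition, with a stated time of 1 h (on this read-out lower numbers stand for stronger inhibition and higher numbers for weaker inhibition), compound 1 `CCOC(=O)c1cnn(-c2nc(-c3ccc(OC)cc3)c(C#N)c(=O)n2C)c1N` gives 68 ug/mL, compound 2 `CCOC(=O)c1cnn(-c2nc(-c3ccccc3F)c(C#N)c(=O)n2C)c1N` gives 94 ug/mL and compound 3 `CCOC(=O)c1cnn(-c2nc(-c3ccccc3O)c(C#N)c(=O)n2C)c1N` gives 57 ug/mL. These three values cannot be told apart, so the number for compound 3 sets no clear rank within the set. The next structure is compound 4 `CCOC(=O)c1cnn(-c2nc(-c3cccs3)c(C#N)c(=O)n2C)c1N`, with thiophen-2-yl in place of 2-hydroxyphenyl on an aromatic carbon. Within the data shown here, no measured compound carries a five-membered aromatic ring at this place, so the evidence is indirect. Three measured steps change the group at this same place: a 1.4-fold higher number from compound 1 to compound 2 (0.14 log units; within the scatter), a 1.2-fold lower number from compound 1 to compound 3 (0.08 log units; within the scatter) and a 1.6-fold lower number from compound 2 to compound 3 (0.22 log units; within the scatter). All three stay within the scatter, including the step that replaces hydroxy with fluoro. On that basis, no change beyond the scatter is expected, and the estimated step is a 1.2-fold higher number from compound 3 to compound 4 (0.09 log units; within the scatter). For compound 4 the estimated value in this assay is 70 ug/mL, with an expected range of 35 ug/mL to 135 ug/mL.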

Compound 4, half-maximal inhibitory concentration: 97 ug/mL
For compound 4 the middle estimate is 1.4-fold (0.14 log units) below the measured one; measured number inside the range.
By their numbers in this assay, from the lowest: compounds 3, 1, 2 and 4 (each within the scatter of the next).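

In this assay thiophen-2-yl gives a 1.7-fold higher number from compound 3 to compound 4 (0.23 log units; within the scatter) and a 1.0-fold higher number from compound 2 to compound 4 (0.01 log units; within the scatter) and a 1.4-fold higher number from compound 1 to compound 4 (0.15 log units; within the scatter) so the step from each of the three six-membered aromatic groups stays within the scatter. The groups read at this place now include a five-membered aromatic ring with a sulfur hetero atom, and a group with no hydrogen-bond donor reads the same as 2-hydroxyphenyl, which has one. No evidence is available that bears on this result.

As far as these compounds go, all four compounds lie within the scatter of one another, so it remains open whether any group at this place can move the number beyond it. An amine or a carboxylic acid here, or a saturated ring such as cyclohexyl, could answer that.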